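The compounds below may be only part of what the source reports. "The series", "measured", "known", "first", "only" and "open" are said of these compounds alone.

Measured compounds in an ADME assay on HEL cells (Homo sapiens) for cytotoxicity, with a stated time of 3 days; a lower number here means that less compound is tolerated, a higher number that more compound is tolerated:
compound 1 `Cc1cn([C@@H]2O[C@H](CO[Si](C)(C)C(C)(C)C)[C@@]3(OS(=O)(=O)C=C3NC(=O)NC(=O)c3ccccc3)[C@H]2O)c(=O)n(C)c1=O`: > 100000 nM
compound 2 `Cc1cn([C@@H]2O[C@H](CO[Si](C)(C)C(C)(C)C(C)C)[C@@]3(OS(=O)(=O)C=C3NC(=O)NC(=O)c3ccccc3)[C@H]2O[Si](C)(C)C(C)(C)C)c(=O)n(C)c1=O`: >= 100000 nM
compound 3 `Cc1cn([C@@H]2O[C@H](CO[Si](C)(C)C(C)(C)C)[C@@]3(OS(=O)(=O)C=C3NC(=O)NC(=O)c3ccccc3)[C@H]2O[Si](C)(C)C(C)(C)C(C)C)c(=O)n(C)c1=O`: >= 100000 nM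

Each of the three values given for compounds 1 to 3 is a limit of this assay and not a number. Compound 3 stands at the limit of >= 100000 nM in this assay, at which 2 of the 3 values shown sit. Compound 2 stands at the same limit. Compound 1 stands at the limit of > 100000 nM in this assay, at which 1 of the 3 values shown sits. For the measured compounds named here, the only step between measured compounds that differ in one place, a step that the two limits leave unreadable from compound 1 to compound 3, cannot be read, since both of its ends are limits; it also lies at a different position from the change considered here.

Compound 4 `Cc1cn([C@@H]2O[C@H](CO[Si](C)(C)C(C)(C)C(C)C)[C@@]3(OS(=O)(=O)C=C3NC(=O)NC(=O)c3ccccc3)[C@H]2O[Si](C)(C)C(C)(C)C(C)C)c(=O)n(C)c1=O` differs from compound 3 by isopropyl in place of methyl on a saturated chain carbon bound to two saturated chain carbons and a silicon atom. Going by the values given here, no measured step bears on this change in this assay. What the series shows is that every measured compound, whatever its silicon-bearing groups, tolerates compound up to the limit of the assay, and there is no reading that would separate the compounds from one another.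

On that basis the expected step is a number no higher from compound 3 to compound 4 (the limit leaves the size open), that is none beyond the scatter. Compound 4 is estimated at 100000 nM, with a range from 50000 nM to 200000 nM, and is most likely to be reported as a limit once more.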

Compound 4, minimum cytotoxic concentration: >= 100000 nM
Compound 4 gave a limit, no number; the forecaster's own chance of this, stated with the estimate: 90%; the middle value lies on the limit itself.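

In this assay compound 4 gives >= 100000 nM, which is a limit and not a number. No new step can be read from compound 3 to compound 4 or from compound 2 to compound 4, as both ends of each pair are limits. The compounds shown leave open where the actual minimum cytotoxic concentration of each lies and whether the silicon-bearing groups separate them at all.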